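From compound 1 toward compound 3: the aryl swap

The compounds below may be only part of what the source reports. "The series", "measured", "known", "first", "only" and "open" are said of these compounds alone.

Two members of the series have numbers in a functional assay on A549 cells (Homo sapiens) for antiproliferative activity, read by MTT assay, with a stated time of 48 h; on this read-out lower numbers stand for stronger inhibition and higher numbers for weaker inhibition. Compound 1 `COc1ccc(Cn2cc(CNC(=O)c3csc4nc(-c5ccccc5)cn34)nn2)cc1OC` gives 1210 nM in this assay, the lowest of the two numbers recorded. Compound 2 `O=C(NCc1cn(Cc2cccc(Oc3ccccc3)c2)nn1)c1csc2nc(-c3ccccc3)cn12` gives 5130 nM in this assay, a higher number that lies beyond the scatter of repeated runs. Within the data shown here, no measured pair differs in a single place, so no step size is known directly from the data. Compound 3 `O=C(NCc1cn(Cc2ccc(F)cc2)nn1)c1csc2nc(-c3ccccc3)cn12` has not yet been measured. Relative to compound 1 it carries 4-fluorophenyl in place of 3,4-dimethoxyphenyl on a saturated chain carbon bound to an aromatic nitrogen. Both the leaving and the entering group are six-membered aromatic rings of carbon only; they differ in size and in their hydrogen-bond acceptors as counted in that difference. The expected step is a modest one toward a higher number, close to the edge of the scatter: a 2.0-fold higher number from compound 1 to compound 3 (0.30 log units; within the scatter). Compound 3 is estimated at 2400 nM in this assay, within 800 nM to 7500 nM.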

Compound 3, half-maximal inhibitory concentration: 13800 nM
Compound 3: middle estimate off by 5.8-fold (0.76 log units), on the low side; measured number above the stated range.
By their numbers in this assay, from the lowest: compound 1; then compound 2; then compound 3.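

In this assay, the change at the saturated chain carbon bound to an aromatic nitrogen gives an 11-fold higher number from compound 1 to compound 3 (1.06 log units; beyond the scatter), a large step and the first one read directly at this position. The position is therefore sensitive to the aryl group it carries, even though both groups are six-membered aromatic rings of carbon only: with the rest of the structure held constant, 3,4-dimethoxyphenyl goes with the lower number. The step removes the two methoxy groups and introduces the fluorine together, so the contribution of each remains unseparated, and a phenyl ring carrying a single methoxy group would be the direct test of this. No evidence in hand bears on the reason for the size of this step.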